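A few compounds are considered here, and "the series" means these few. Any claim that something is new, unique, unknown or untested is made for them only; others in the source may bear on it.

Compound 1 `COc1ccccc1Oc1c(N)nc(-c2ccccc2)nc1Cl`: 4610 nM
Compound 2 `COc1ccccc1Oc1c(N)nc(-c2cccc(C)c2)nc1Cl`: 13100 nM
Compound 3 `COc1ccccc1Oc1c(N)nc(-c2cccc(Cl)c2)nc1Cl`: 17900 nM

All three values come from a functional assay on B16 cells (Mus musculus) for cytotoxicity, read by CCK-8 assay, with a stated time of 24 h; on this read-out higher numbers stand for weaker inhibition and lower numbers for stronger inhibition. Compound 3, at 17900 nM, cannot be separated from the methyl analogue: a 1.4-fold higher number from compound 2 to compound 3 (0.14 log units; within the scatter). The hydrogen analogue stands clearly apart: a 3.9-fold higher number from compound 1 to compound 3 (0.59 log units; beyond the scatter).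

Compound 4 `COc1ccccc1Oc1c(N)nc(-c2cccc(Br)c2)nc1Cl` carries bromo in place of chloro on an aromatic carbon. Going by the values given here, no measured step covers bromo itself. Two steps from hydrogen bear on this position, the chloro step above and the methyl step, a 2.8-fold higher number from compound 1 to compound 2 (0.45 log units; beyond the scatter). Both are modest and run the same way, and none of the three compounds goes against this. The nearest precedent is the exchange between two substituents at this position, which stayed within the scatter, as shown above for compound 3 at a 1.4-fold higher number from compound 2 to compound 3 (0.14 log units; within the scatter). No step beyond the scatter is therefore expected in this assay. The estimated change is a 1.0-fold higher number from compound 3 to compound 4 (0.00 log units; within the scatter). For compound 4 the expected value is 18000 nM, with an estimated range of 9000 nM to 36000 nM.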

Compound 4, half-maximal inhibitory concentration: 24600 nM
For compound 4 the middle estimate is 1.4-fold (0.14 log units) below the measured one; low and high end bracket the measured number.
By their numbers in this assay, from the lowest: compound 1; then compounds 2, 3 and 4 (each within the scatter of the next).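

In this assay, bromo on this aromatic carbon cannot be separated from chloro (a 1.4-fold higher number from compound 3 to compound 4 (0.14 log units; within the scatter)) or from methyl (a 1.9-fold higher number from compound 2 to compound 4 (0.27 log units; within the scatter)), so the three substituents now form one group within the scatter. Against hydrogen, bromo gives a modest step beyond the scatter (a 5.3-fold higher number from compound 1 to compound 4 (0.73 log units; beyond the scatter)), in the same direction as methyl and chloro; thus all three substituents on this carbon give higher numbers than hydrogen, and no compound shown goes against this. Nothing available explains this separation from hydrogen.

The compounds shown leave open whether an amine or a carboxylic acid on this carbon would also give a higher number than hydrogen. They also leave open whether the bromo step would hold with a different group on the rest of the core.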